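Moving one hydroxyl group around a shared triaryl core

This account rests on a few compounds, and the source may have more. Where it says the series, first, only, none or still open, it means among the compounds named here.

Measured compounds:
compound 1, `Oc1ccc(-c2cc(-c3cccc(O)c3)nc(-c3cccc(O)c3)c2)cc1`, 1760 nM
compound 2, `Oc1cccc(-c2cc(-c3ccccc3O)nc(-c3ccccc3O)c2)c1`, 5400 nM

In a functional assay on DU-145 cells (Homo sapiens) for cytotoxicity, read by CCK-8 assay, with a stated time of 4 days (on this read-out lower numbers stand for stronger inhibition and higher numbers for weaker inhibition), compound 2 gives the highest of the two numbers; the nearest is compound 1, whose number is lower by a margin beyond the usual scatter. Compound 3, `Oc1cccc(-c2cc(-c3cccc(O)c3)nc(-c3ccccc3O)c2)c1`, has not been measured. It differs from compound 2 in one place: 3-hydroxyphenyl in place of 2-hydroxyphenyl on an aromatic carbon. Within the data shown here, with no measured pair that isolates this change, the size of the step is uncertain. Among the measured compounds shown here, the only guide is that compound 1, which carries two 3-hydroxyphenyl groups, gave 1760 nM, a lower number than compound 2. On that basis compound 3 is expected to move part of the way toward compound 1, and the expected step from compound 2 to compound 3 is a 1.8-fold lower number from compound 2 to compound 3 (0.26 log units; within the scatter). Compound 3 is estimated at 3000 nM, with a range from 1200 nM to 8000 nM.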

Compound 3, half-maximal inhibitory concentration: > 50000 nM
Compound 3: a limit, no number; the forecaster's own chance of this, stated with the estimate: 5%; at least 16-fold (1.22 log units) between middle value and limit.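

In this assay compound 3 gives > 50000 nM, which is a limit of the assay and not a number. Putting 3-hydroxyphenyl in place of 2-hydroxyphenyl on the aromatic carbon next to the ring nitrogen leaves the heavy atoms and the counted donors and acceptors unchanged, yet it gives an at least 9.2-fold higher number from compound 2 to compound 3 (0.96 log units; beyond the scatter), so at this position the place of the hydroxyl on the ring alone decides the outcome, something compounds 1 and 2, which differ in more than one place, could not show. The step has a lower bound only, and its full size stays unknown: the limit of > 50000 nM in this assay, at which 1 of the 3 values shown sits.

The compounds shown leave open whether a methoxy group or an amine in place of the hydroxyl on this 2-hydroxyphenyl ring would keep the number of compound 2. They also do not show whether the same change behaves alike on the other positions of the shared core.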